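Chloro at the ring-nitrogen-adjacent carbon of compound 2

The source may hold more compounds than are shown below. What is called first, only, known or untested is meant among the compounds shown, and "the series" means these compounds.

Compound 2 `Fc1cccc(F)c1C#Cc1ccc2ncccc2c1` stands highest of the two numbers measured in a functional assay on LS174T cells (Homo sapiens) for inhibition, with a stated time of 4 days, tested at 10 uM (a higher number here means a stronger effect of the compound at the concentration tested, a lower number a weaker effect), where compound 2 gives 80.1%. Its nearest neighbour is compound 1 `CN(C)c1ccc2cc(C#Cc3c(F)cccc3F)ccc2n1`; in this assay compound 1 gives 38.7%. Among the compounds with values here, the one measured step, a number 41.4 percentage points higher from compound 1 to compound 2 (beyond the scatter), shows that removing the dimethylamino group from an aromatic carbon of the shared core raised the read-out strongly.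

Compound 3 `Fc1cccc(F)c1C#Cc1ccc2nc(Cl)ccc2c1` is not yet measured. It differs from compound 2 by chloro in place of hydrogen on an aromatic carbon. Within the data shown here, the only step that bears on it is that from compound 1 to compound 2, which was large and ran upward on removal of a substituent from an aromatic carbon. Placing a chloro group onto the core of compound 2 is therefore expected to move the read-out downward, though a chloro group is a smaller entry than dimethylamino, so a step smaller than a number 41.4 percentage points higher from compound 1 to compound 2 (beyond the scatter) is expected, namely a number 22.1 percentage points lower from compound 2 to compound 3 (beyond the scatter). Compound 3 is estimated at 58% in this assay, with a range from 25% to 88%.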

Compound 3, a percentage reported as inhibition, at one concentration (the size of the read-out at that concentration, not a potency): 63.3%
Compound 3: middle estimate off by 5.3 percentage points, on the low side, and the stated range covers the measured number.
By their numbers in this assay, from the lowest: compound 1; then compound 3; then compound 2.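

In this assay the position next to the ring nitrogen now has three entries, and the read-out falls in the order hydrogen, chloro, dimethylamino. Chloro in this position gives a number 16.8 percentage points lower from compound 2 to compound 3 (beyond the scatter) and, set against dimethylamino, gives a number 24.6 percentage points higher from compound 1 to compound 3 (beyond the scatter) so the loss seen with substitution here is not confined to dimethylamino, and a single chlorine atom is enough to produce a smaller one. Within the data shown here, nothing measured so far accounts for these differences.

On these data alone, whether that order extends to fluoro, methyl, methoxy or a primary amine at this position remains open, since three entries fix no trend in group size or type. Also open, as far as these compounds go, is whether chloro on another aromatic carbon of the shared core would lower the read-out in the same way.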